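Taking the chloro group off compound 2

A few compounds are considered here, and "the series" means these few. Any claim that something is new, unique, unknown or untested is made for them only; others in the source may bear on it.

In a functional assay on A549 cells (Homo sapiens) for inhibition, with a stated time of 72 h (on this read-out higher numbers stand for weaker inhibition and lower numbers for stronger inhibition), compound 1 (`Cc1ccc(C)c(NC(=O)Nc2nc(Sc3c[nH]c4ccccc34)cc(N3CCCCC3)n2)c1`) gives 25400 nM and compound 2 (`O=C(Nc1ccc(Cl)cc1)Nc1nc(Sc2c[nH]c3ccccc23)cc(N2CCCCC2)n1`) gives 18600 nM, so the two sit within the scatter of each other. Compound 3 (`O=C(Nc1ccccc1)Nc1nc(Sc2c[nH]c3ccccc23)cc(N2CCCCC2)n1`) has hydrogen in place of chloro on an aromatic carbon, para to a large group: hydrogen in place of chloro on an aromatic carbon. Among the measured compounds shown here, only one measured step bears on this, and only loosely, since it changed the same group: a 1.4-fold lower number from compound 1 to compound 2 (0.14 log units; within the scatter). No step beyond the scatter is therefore expected in this assay. The expected change is a 1.2-fold higher number from compound 2 to compound 3 (0.09 log units; within the scatter). Compound 3 is estimated at 23000 nM, within a range from 11000 nM to 48000 nM.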

Compound 3, half-maximal inhibitory concentration: 33100 nM
Compound 3: the middle estimate sits 1.4-fold (0.16 log units) below what was measured; measured number inside the range.
By their numbers in this assay, from the lowest: compounds 2, 1 and 3 (each within the scatter of the next).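

In this assay, hydrogen in place of chloro on this aromatic carbon stays within the scatter (a 1.8-fold higher number from compound 2 to compound 3 (0.25 log units; within the scatter)). Phenyl in place of 2,5-dimethylphenyl also stays within it (a 1.3-fold higher number from compound 1 to compound 3 (0.11 log units; within the scatter)), so the bare phenyl ring sits in the same range as both substituted rings. No measurement shown offers an explanation for these small differences. As far as these compounds go, what remains open is whether an amine, a carboxylic acid or a longer chain on this aromatic carbon would produce a step beyond the scatter.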